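This account rests on a few compounds, and the source may have more. Where it says the series, first, only, none or still open, it means among the compounds named here.

Working notes on the series, all values from a functional assay on NCI-H1993 cells (Homo sapiens) for inhibition, read by CCK-8 assay, with a stated time of 72 h; a higher number here means a weaker inhibitor, a lower number a stronger inhibitor:

- compound 1 `CC(c1cc2cccnc2cc1F)n1cnc2ncc(-c3cnn(C)c3)nc21`: 31.3 nM
- compound 2 `CCC(c1ccc2ncccc2c1F)n1cnc2ncc(-c3cnn(CCO)c3)nc21`: "not determined" (no result reported)
- compound 3 `CC(c1cc(F)c2ncccc2c1)n1cnc2ncc(-c3ccncc3)nc21`: > 10000 nM

Compound 2 has no number to work from, as its entry reads "not determined" (no result reported). Compound 3 gives > 10000 nM, which is a limit of the assay and not a number. For the measured compounds named here, compound 1, at 31.3 nM, is thus the only measured number in the set.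

Compound 4 `CCC(c1ccc2ncccc2c1F)n1cnc2ncc(-c3ccc(C(N)=O)c(F)c3)nc21` has yet to be measured in this assay. The step 4-carbamoyl-3-fluorophenyl in place of 1-(2-hydroxyethyl)-1H-pyrazol-4-yl on an aromatic carbon puts 4-carbamoyl-3-fluorophenyl in place of 1-(2-hydroxyethyl)-1H-pyrazol-4-yl on an aromatic carbon of a six-membered aromatic ring with 2 nitrogen, part of a fused or bridged system of two rings.

Going by the values given here, no measured step in the set shows what this exchange does, and compound 2 offers no starting number. The working expectation is therefore no step beyond the scatter in this assay, and no direction is assumed. This is a weakly held expectation that places the new compound in the region of compound 1 at 31.3 nM, with a wide margin on the weak side.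

In this assay the estimate for compound 4 is 40 nM, expected to lie between 5 nM and 400 nM.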

Compound 4, half-maximal inhibitory concentration: 665 nM
The estimate for compound 4 lay 17-fold (1.22 log units) below the measured number; measured number outside the range, above it.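

No new step can be read: in this assay compound 4 gives 665 nM, while compound 2, which differs from it in one place, has the entry "not determined" (no result reported). The compounds shown leave open how 4-carbamoyl-3-fluorophenyl compares with 1-(2-hydroxyethyl)-1H-pyrazol-4-yl on the shared core in this assay.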